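Pyridin-3-yl in place of 3-chlorophenyl on the shared core

The source may report more compounds than this note shows. Statements on the series, on what has been measured and on what is new or still open speak of the compounds shown alone.

Compound 2 `COc1ccc2c(c1)OC(N)=C(C#N)C2c1cccc(Cl)c1` stands second highest of the three numbers measured in a functional assay on T47D cells (Homo sapiens) for activation (on this read-out higher numbers stand for an effect only at larger amounts of compound and lower numbers for an effect already at smaller amounts), giving 80000000 nM. Its nearest neighbour is compound 3 `COc1cccc(C2C(C#N)=C(N)Oc3cc(OC)ccc32)c1`, where a 1.5-fold lower number from compound 2 to compound 3 (0.19 log units; within the scatter); its furthest is compound 1 `COc1ccc2c(c1)OC(N)=C(C#N)C2c1ccccc1`, which in this assay gives 360000000 nM, while compound 3 gives 52000000 nM. Compound 4 `COc1ccc2c(c1)OC(N)=C(C#N)C2c1cccnc1` differs from compound 2 in that (pyridin-3-yl in place of 3-chlorophenyl on a saturated ring carbon). The steps known so far, a 4.5-fold lower number from compound 1 to compound 2 (0.65 log units; beyond the scatter) and a 1.5-fold lower number from compound 2 to compound 3 (0.19 log units; within the scatter), concern substituents on the 3-chlorophenyl rather than its exchange for pyridin-3-yl, so they bear only loosely on this change. The step of no change at the digits printed from compound 2 to compound 4 (within the scatter) is therefore expected to stay within the scatter. In this assay compound 4 is estimated at 80000000 nM, with a range from 20000000 nM to 400000000 nM.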

Compound 4, half-maximal effective concentration: 170000000 nM
For compound 4 the middle estimate is 2.1-fold (0.33 log units) below the measured one; the measured number falls inside the stated range.
By their numbers in this assay, from the lowest: compounds 3 and 2 (each within the scatter of the next); then compound 4; then compound 1.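

The exchange of the whole aromatic ring on the saturated ring carbon now has a reading in this assay: pyridin-3-yl in place of 3-chlorophenyl gives a 2.1-fold higher number from compound 2 to compound 4 (0.33 log units; beyond the scatter), while pyridin-3-yl in place of phenyl gives a 2.1-fold lower number from compound 1 to compound 4 (0.33 log units; beyond the scatter). Compound 4 therefore sits between compound 2 and compound 1, so this position tolerates a ring with a hetero atom without matching the 3-chlorophenyl number. No evidence is available to explain these steps. Left open is how pyridin-4-yl or pyridin-2-yl would read at this carbon, and whether an amine or a carboxylic acid on the ring would shift the number further.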